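A Dichlorophenyl Ring in Place of Fluorophenyl

The compounds below may be only part of what the source reports. "The series", "measured", "known", "first", "only" and "open" are said of these compounds alone.

Compound 2 `CN(C)CCn1cnnc1-c1cc(Oc2ccc(NC(=O)N/N=C/c3ccc(O)c(Br)c3)cc2F)ccn1`: 5560 nM
Compound 3 `CN(C)CCn1cnnc1-c1cc(Oc2ccc(NC(=O)N/N=C/c3ccc(F)cc3)cc2F)ccn1`: 3980 nM
Compound 1 `CN(C)CCn1cnnc1-c1cc(Oc2ccc(NC(=O)N/N=C/c3ccc(O)c(F)c3)cc2F)ccn1`: "not determined" (no result reported)

These compounds share one core and differ only in the ring attached to a carbon with a double bond to nitrogen. In an ADME assay on WI-38 cells (Homo sapiens) for cytotoxicity, read by MTT assay, with a stated time of 72 h (a higher number here means a weaker inhibitor, a lower number a stronger inhibitor), compound 2 gives 5560 nM and compound 3 gives 3980 nM; compound 3 thus stands at the lower of the two numbers, though the gap a 1.4-fold lower number from compound 2 to compound 3 (0.15 log units; within the scatter) lies within the scatter. For compound 1 the result in this assay is "not determined" (no result reported). Compound 4 `CN(C)CCn1cnnc1-c1cc(Oc2ccc(NC(=O)N/N=C/c3c(Cl)cccc3Cl)cc2F)ccn1` carries 2,6-dichlorophenyl in place of 4-fluorophenyl on a carbon with a double bond to nitrogen. Within the data shown here, the only step that bears on this exchange is a 1.4-fold lower number from compound 2 to compound 3 (0.15 log units; within the scatter), which changed the same ring and stayed within the scatter, so no step beyond the scatter is expected in this assay. Compound 4 is therefore expected to give 4000 nM (range 1500 nM to 12000 nM). The implied step, a 1.0-fold higher number from compound 3 to compound 4 (0.00 log units; within the scatter), is expected to stay within the scatter.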

Compound 4, half-maximal inhibitory concentration: 3320 nM
Compound 4: the middle estimate sits 1.2-fold (0.08 log units) above what was measured; low and high end bracket the measured number.
By their numbers in this assay, from the lowest: compounds 4, 3 and 2 (each within the scatter of the next).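

In this assay the step of a 1.2-fold lower number from compound 3 to compound 4 (0.08 log units; within the scatter) and the step of a 1.7-fold lower number from compound 2 to compound 4 (0.22 log units; within the scatter) both stay within the scatter, so 2,6-dichlorophenyl cannot be told apart from either earlier ring. All three rings on a carbon with a double bond to nitrogen thus give numbers within the scatter of one another, now including a ring with two chlorine atoms. Nothing measured here offers an explanation for this result.

Still open, on these data alone, is whether a phenyl ring bearing an amine or a carboxylic acid would give a step beyond the scatter. The same question stands for a longer chain in place of the ring.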